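Nucleoside series: furan-2-yl replacing phenyl

The source may report more compounds than this note shows. Statements on the series, on what has been measured and on what is new or still open speak of the compounds shown alone.

Measured in a functional assay on K562 cells (Homo sapiens), read by MTT assay, with a stated time of 72 h; a higher number here means a weaker inhibitor, a lower number a stronger inhibitor:

compound 1 `CSc1ncnc2c1c(-c1ccccc1)cn2[C@@H]1O[C@H](CO)[C@@H](O)[C@H]1O`, > 20000 nM, a limit of the assay
compound 2 `COc1ncnc2c1c(-c1ccccc1)cn2[C@@H]1O[C@H](CO)[C@@H](O)[C@H]1O`, > 20000 nM, a limit of the assay
compound 3 `CNc1ncnc2c1c(-c1ccccc1)cn2[C@@H]1O[C@H](CO)[C@@H](O)[C@H]1O`, > 20000 nM, a limit of the assay

None of the three compounds returns a number; each sits at the limit, as noted in the limit of > 20000 nM in this assay, at which 3 of the 3 values shown sit. The three steps among them therefore cannot be read: a step that the two limits leave unreadable from compound 1 to compound 2, a step that the two limits leave unreadable from compound 1 to compound 3 and a step that the two limits leave unreadable from compound 2 to compound 3. Compound 3 thus stands nowhere in particular on the numbers shown; it shares a limit with the other two, and no order among them can be stated.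

Compound 4 `CNc1ncnc2c1c(-c1ccco1)cn2[C@@H]1O[C@H](CO)[C@@H](O)[C@H]1O` is not yet measured. It differs from compound 3 as follows: furan-2-yl in place of phenyl on an aromatic carbon. Going by the values given here, no measured step touches the phenyl; all three concern the group on the other aromatic carbon of the shared core, and all are unreadable. Nothing shown therefore bears on the change to furan-2-yl, and the scale of any effect is unknown.

With every value at the limit, the expectation for compound 4 in this assay is that it also reports a limit rather than a number, an estimated 20000 nM with a range of 5000 nM to 20000 nM. The step this estimate implies, a number no higher from compound 3 to compound 4 (the limit leaves the size open), is expected to be unreadable as well.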

Compound 4, half-maximal inhibitory concentration: 220 nM
For compound 4 the middle estimate is 91-fold (1.96 log units) above the measured one; measured number below the stated range.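

In this assay, with methylamino held constant on the other aromatic carbon, the position two ring bonds from the ring nitrogen proves sensitive to its aromatic group: furan-2-yl in place of phenyl gives an at least 90-fold lower number from compound 3 to compound 4 (1.95 log units; beyond the scatter). Compound 3 gives > 20000 nM, a limit of the assay. This single pair shows that the phenyl group, common to compound 1, compound 2 and compound 3, can be exchanged with a large effect, but the true size of the step remains unknown because one end of it rests on a limit: the limit of > 20000 nM in this assay, at which 3 of the 4 values shown sit.

The steps among compound 1, compound 2 and compound 3 cannot be read, and furan-2-yl is shown only with methylamino, so it remains open whether methylsulfanyl or methoxy on that carbon would give a similar result alongside furan-2-yl. Also open, going by these compounds, is whether the effect is specific to furan-2-yl or extends to related groups such as furan-3-yl, thiophen-2-yl or pyrrol-2-yl.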